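This account rests on a few compounds, and the source may have more. Where it says the series, first, only, none or still open, it means among the compounds named here.

Compound 1 `CN[C@@H](CC(C)C)CN(C(=O)[C@@H]1C[C@H]1c1ccccc1)c1ccc(-c2ccccc2)cc1` is one of two compounds already measured in a functional assay for agonist activity at G protein-coupled receptor 88 (Homo sapiens), read by HTRF and cAMP accumulation; on this read-out higher numbers stand for an effect only at larger amounts of compound and lower numbers for an effect already at smaller amounts. In this assay compound 1 gives 2 nM. Among the measured compounds shown here, compound 2 `CC[C@H](C)[C@H](N)CN(C(=O)[C@@H]1C[C@H]1c1ccccc1Cl)c1ccc(-c2ccccc2)cc1` differs from compound 1 in more than one place, so no single step between the two can be read. For compound 2 this assay reports only a limit, > 25000 nM, which is not a number but the edge of what the assay can report. This is the limit of > 25000 nM in this assay, at which 1 of the 2 values shown sits. Compound 3 `CC[C@H](C)[C@H](N)CN(C(=O)[C@@H]1C[C@H]1c1ccncc1)c1ccc(-c2ccccc2)cc1` has not yet been measured. It differs from compound 2 in one place: pyridin-4-yl in place of 2-chlorophenyl on a saturated ring carbon. No measured pair shows this change, so its size is unknown from the numbers shown; with compound 2 at the limit, the step from compound 2 to compound 3 is expected to be none beyond the scatter, with a limit again the most likely outcome. Compound 3 is expected to give about 25000 nM, within 5000 nM to 50000 nM, an expected step of a number no higher from compound 2 to compound 3 (the limit leaves the size open).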

Compound 3, half-maximal effective concentration: 1500 nM
For compound 3 the middle estimate is 17-fold (1.22 log units) above the measured one, and the stated range ends above it.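

On the saturated ring carbon of the three-membered ring, pyridin-4-yl in place of 2-chlorophenyl gives an at least 16-fold lower number from compound 2 to compound 3 (1.22 log units; beyond the scatter) in this assay. Among the compounds shown here, this is the first single change that can be read here, and it shows that the aromatic ring at this place matters: with the rest of the molecule unchanged, swapping this one group brings a measurable value where there was only a limit. The full size of the step stays open because compound 2 gives a limit and not a number: the limit of > 25000 nM in this assay, at which 1 of the 3 values shown sits.

In this one step a ring nitrogen enters and a chlorine leaves, and the compounds shown do not tell these two apart. Nor do they show how pyridin-3-yl or 4-fluorophenyl would read at this place, or whether the same change would hold on the side chain of compound 1.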